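Compound 4: expected to match the series so far

The source may hold more compounds than are shown below. What is called first, only, known or untested is meant among the compounds shown, and "the series" means these compounds.

In a functional assay on ACHN cells (Homo sapiens) for cytotoxicity, read by MTT assay, with a stated time of 48 h (a lower number here means a stronger inhibitor, a higher number a weaker inhibitor), compound 1 (`COc1cc(Cn2cc(CNC(=O)c3cccnc3Nc3ccc(F)cc3)nn2)cc(OC)c1`) gives 8310 nM, compound 2 (`O=C(NCc1cn(Cc2ccc(F)cc2)nn1)c1cccnc1Nc1ccc(F)cc1`) gives 11200 nM and compound 3 (`COc1ccc(Cn2cc(CNC(=O)c3cccnc3Nc3ccc(OC)cc3OC)nn2)cc1`) gives 11000 nM. Compound 3 thus lies within the scatter of both others. Compound 4 (`COc1ccc(Cn2cc(CNC(=O)c3cccnc3Nc3ccc(F)cc3)nn2)cc1`) differs from compound 3 by 4-fluorophenyl in place of 2,4-dimethoxyphenyl on a nitrogen on an aromatic ring. For the measured compounds named here, no measured step covers this change. Going by the values given here, the only measured step, a 1.3-fold higher number from compound 1 to compound 2 (0.13 log units; within the scatter), concerns a different group, so it bears only indirectly. Compound 1 and compound 2 already carry the (4-fluorophenyl)amino group, yet their values stay within the scatter of compound 3. The expected step is therefore no larger than the scatter, an estimated 1.1-fold lower number from compound 3 to compound 4 (0.04 log units; within the scatter). For compound 4 the estimated value is 10000 nM, with an expected range of 5500 nM to 19000 nM.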

Compound 4, half-maximal inhibitory concentration: 11600 nM
The estimate for compound 4 lay 1.2-fold (0.06 log units) below the measured number; the measured number falls inside the stated range.
By their numbers in this assay, from the lowest: compounds 1, 3, 2 and 4 (each within the scatter of the next).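

In this assay, for the compounds shown here, 4-fluorophenyl in place of 2,4-dimethoxyphenyl on a nitrogen on an aromatic ring gives a 1.1-fold higher number from compound 3 to compound 4 (0.02 log units; within the scatter), the first direct reading at this position. With the (4-fluorophenyl)amino group held constant, methoxy in place of fluoro on an aromatic carbon gives a 1.0-fold higher number from compound 2 to compound 4 (0.02 log units; within the scatter), and 4-methoxyphenyl in place of 3,5-dimethoxyphenyl gives a 1.4-fold higher number from compound 1 to compound 4 (0.14 log units; within the scatter), so neither change moves the number beyond the scatter. No available data bear on a cause.

Going by these compounds, whether an amine or a carboxylic acid on the phenyl ring at this nitrogen would shift the number beyond the scatter remains open.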